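Cytotoxicity notes: one methyl-to-chloro swap, made twice

A few compounds are considered here, and "the series" means these few. Any claim that something is new, unique, unknown or untested is made for them only; others in the source may bear on it.

Four compounds share a common core. Compound 1 `Cc1cccc(C(=O)c2c(OCC(=O)Nc3ccc(S(N)(=O)=O)cc3C)ccc3cc(Br)ccc23)c1` and compound 2 `Cc1cc(S(N)(=O)=O)ccc1NC(=O)COc1ccc2cc(Br)ccc2c1C(=O)c1cccc(Cl)c1` are separated only by chloro in place of methyl on an aromatic carbon. Compound 3 `Cc1cccc(C(=O)c2c(OCC(=O)Nc3ccc(S(N)(=O)=O)cc3C)ccc3cc(C#N)ccc23)c1` is set apart from compound 1 by cyano in place of bromo on an aromatic carbon. Compound 4 `Cc1cc(S(N)(=O)=O)ccc1NC(=O)COc1ccc2cc(C#N)ccc2c1C(=O)c1cccc(Cl)c1`, not yet measured, is set apart from compound 3 by chloro in place of methyl on an aromatic carbon; the place is described in the same words for both pairs, so this is the same change as between compound 1 and compound 2, occurring twice among the compounds shown.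

In an ADME assay on C8166 cells (Homo sapiens) for cytotoxicity, read by colorimetric assay and MTT assay (a lower number here means that less compound is tolerated, a higher number that more compound is tolerated), compound 1 gives 6800 nM. Compound 2 gives 6800 nM in this assay. Compound 3 gives 15200 nM in this assay, the highest of the three. The measured steps are no change at the digits printed from compound 1 to compound 2 (within the scatter) and a 2.2-fold higher number from compound 1 to compound 3 (0.35 log units; beyond the scatter). Among the measured compounds shown here, only one prior instance of the methyl-to-chloro change exists, so support is thin.

For compound 4 the expected step is a 1.0-fold lower number from compound 3 to compound 4 (0.01 log units; within the scatter), resting on no change at the digits printed from compound 1 to compound 2 (within the scatter). The estimate for compound 4 in this assay is 15000 nM. For compound 4 the expected range runs from 7500 nM to 30000 nM.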

Compound 4, half-maximal cytotoxic concentration: > 374000 nM
Compound 4 gave a limit, no number (the forecaster's own chance of this, stated with the estimate: 5%); middle value at least 24-fold (1.39 log units) from the limit.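

In this assay compound 4 gives > 374000 nM, a limit of the assay and not a number. Chloro in place of methyl gives an at least 24-fold higher number from compound 3 to compound 4 (1.39 log units; beyond the scatter) and cyano in place of bromo gives an at least 55-fold higher number from compound 2 to compound 4 (1.74 log units; beyond the scatter), so the size of the chloro step does not carry from the core of compound 1 to the core of compound 3: the same change on two cores in this assay, no change at the digits printed (within the scatter) from compound 1 to compound 2 and an at least 24-fold higher number (1.39 log units; beyond the scatter) from compound 3 to compound 4, at least 24-fold (1.39 log units) apart, beyond the scatter of two such steps. On these data alone, the cyano step likewise differs between its two pairs, but both large steps rest on the limit, so their true size remains unknown, and two pairs give no rule for any further core: the same change on two cores in this assay, a 2.2-fold higher number (0.35 log units; beyond the scatter) from compound 1 to compound 3 and an at least 55-fold higher number (1.74 log units; beyond the scatter) from compound 2 to compound 4, at least 24-fold (1.39 log units) apart, beyond the scatter of two such steps.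

Still open, as far as these compounds go, is whether the jump at compound 4 is specific to chloro and cyano together, or would also appear with another group in that place. A fluoro or methoxy group in place of the chloro on the core of compound 4, or an amine in place of the cyano, would bear on that question.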